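Adding a sulfonyl group to compound 3

The compounds below may be only part of what the source reports. "The series", "measured", "known", "first", "only" and "open" are said of these compounds alone.

Among the compounds with values here, in a functional assay on QGY-7703 cells (Homo sapiens) for cytotoxicity, read by MTT assay, with a stated time of 24 h (a higher number here means a weaker inhibitor, a lower number a stronger inhibitor), compound 3 `O=C1/C(=C/c2cccnc2)CNC/C1=C\c1ccccc1C(F)(F)F` gives 3800 nM, the lowest of the three numbers so far. Compound 1 `O=C1/C(=C/c2cccnc2)CNC/C1=C\c1ccccc1F` gives 8890 nM and compound 2 `N#Cc1ccc(S(=O)(=O)N2C/C(=C\c3ccncc3)C(=O)/C(=C/c3ccccc3F)C2)cc1` gives 8500 nM, two values within the scatter of each other. Within the data shown here, the only measured step, a 2.3-fold lower number from compound 1 to compound 3 (0.37 log units; beyond the scatter), exchanged fluoro for trifluoromethyl and does not touch the site changed here.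

Compound 4 `N#Cc1ccc(S(=O)(=O)N2C/C(=C\c3cccnc3)C(=O)/C(=C/c3ccccc3C(F)(F)F)C2)cc1` keeps the trifluoromethyl group and places (4-cyanophenyl)sulfonyl in place of hydrogen on an amine nitrogen in a ring. Among the measured compounds shown here, no measured pair isolates this change. The closest evidence is compound 2, which carries the same group but also differs from compound 1 elsewhere in the structure. Compound 2 gives 8500 nM and compound 1 gives 8890 nM, two values within the scatter of each other, so no step beyond the scatter is expected in this assay. The expected step is a 1.1-fold lower number from compound 3 to compound 4 (0.04 log units; within the scatter). Compound 4 is estimated at 3500 nM, with an expected range of 1500 nM to 8000 nM.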

Compound 4, half-maximal inhibitory concentration: 6150 nM
Beside the measured number, compound 4's estimate is 1.8-fold (0.24 log units) below it; low and high end bracket the measured number.
By their numbers in this assay, from the lowest: compounds 3, 4, 2 and 1 (each within the scatter of the next, the first and the last beyond it).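

In this assay, within the data shown here, a 1.6-fold higher number from compound 3 to compound 4 (0.21 log units; within the scatter) is the first measured pair that isolates (4-cyanophenyl)sulfonyl in place of hydrogen on an amine nitrogen in a ring, a reading the earlier compounds could not give, since compound 2 also differs from compound 1 elsewhere. The step lies within the scatter, so with trifluoromethyl and the rest of the structure held constant, this position takes a group of 11 heavy atoms, including an aromatic ring and a nitrile, with no change that can be told from the scatter of repeated measurements. The data shown offer no measured explanation for this result.

On these data alone, whether other groups on this nitrogen, such as methylsulfonyl, acetyl or benzyl, would also stay within the scatter remains open. So does whether the step from fluoro to trifluoromethyl holds once the nitrogen carries (4-cyanophenyl)sulfonyl.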